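A few compounds are considered here, and "the series" means these few. Any claim that something is new, unique, unknown or untested is made for them only; others in the source may bear on it.

Measured so far:
compound 1, `Clc1ccc(OCC2=NCCO2)cc1`: 12%
compound 2, `Brc1ccccc1OCC1=NCCO1`: 40%

In a toxicity assay on the whole organism with Rattus norvegicus as the target, at a dose of 400 mg/kg by the oral route (a lower number here means a weaker effect, a higher number a stronger effect of the compound at the dose given), compound 1 gives 12%. Compound 2 gives 40% in this assay, the highest of the two numbers; its nearest neighbour, compound 1, lies lower by a gap beyond the usual scatter. The two structures differ in more than one place, so nothing further is read from that pair.

Compound 3 is `Cc1ccccc1OCC1=NCCO1`, not yet measured in this assay. Relative to compound 2 the change is methyl in place of bromo on an aromatic carbon. Within the data shown here, no comparable step between measured compounds exists, so its size cannot be read from the data. The expected step from compound 2 to compound 3 is a number 12 percentage points lower from compound 2 to compound 3 (beyond the scatter), a modest fall that may well stay within the scatter. For compound 3 the estimate in this assay is 28%, with a range from 8% to 52%.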

Compound 3, a percentage reported as activity, at one dose (the size of the read-out at that dose, not a potency): 40%
Compound 3: the middle estimate sits 12 percentage points below what was measured, within the range that was stated.
By their numbers in this assay, from the lowest: compound 1; then compounds 2 and 3 (each within the scatter of the next).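

In this assay, among these compounds, methyl in place of bromo on an aromatic carbon, ortho to a group of 7 heavy atoms, gives no change at the digits printed from compound 2 to compound 3 (within the scatter), the first step that can be read at a single place. At this position, the read-out at the dose given does not separate these two groups, so bromo is not needed to keep the number. Nothing measured on these compounds explains why the two groups read alike.

On these data alone, whether the same holds at this position for an amine, a carboxylic acid or a longer chain remains open. Among the compounds shown here, compound 1 differs from compound 2 in more than one place, so no step to it can be read, and the role of the position itself stays unsettled.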